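The compounds below may be only part of what the source reports. "The series", "measured", "known", "first", "only" and "open" are said of these compounds alone.

Compound 1 `C=CCn1c(=O)/c(=C\c2cccc(F)c2)[nH]c(=O)/c1=C\c1ccccc1OC` gives 6500 nM in a functional assay on MOLT-4 cells (Homo sapiens) for cytotoxicity, read by CCK-8 assay, with a stated time of 72 h; on this read-out lower numbers stand for stronger inhibition and higher numbers for weaker inhibition. Compound 2 `C=CCn1c(=O)/c(=C\c2ccc(Cl)c(Cl)c2)[nH]c(=O)/c1=C\c1ccccc1OC` carries a 3,4-dichlorophenyl group in place of the 3-fluorophenyl group of compound 1, and in this assay compound 2 is reported as "not active" (no number reported), so no single number stands for it and it cannot be placed on the scale that compound 1 occupies. The step to compound 3 `C=CCn1c(=O)/c(=C\c2ccccc2OC)[nH]c(=O)/c1=C\c1ccccc1OC` is 2-methoxyphenyl in place of 3,4-dichlorophenyl on a double-bonded chain carbon bound to an aromatic carbon, which makes the two benzylidene arms of the shared core the same. Among the measured compounds shown here, since compound 2 gives no number, no measured step can be stated. Compound 1, which already carries one 2-methoxyphenyl group, gives a weak value, and compound 2 gives none, so only a weak outcome is expected for compound 3, with a real chance that no number is reported. Compound 3 is estimated at 12000 nM, with a range from 3000 nM to 50000 nM.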

Compound 3, half-maximal inhibitory concentration: 13100 nM
Compound 3: middle estimate off by 1.1-fold (0.04 log units), on the low side, within the range that was stated.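

In this assay, the place on a double-bonded chain carbon bound to an aromatic carbon now has one readable step, a 2.0-fold higher number from compound 1 to compound 3 (0.30 log units; within the scatter), so 2-methoxyphenyl and 3-fluorophenyl cannot be told apart there. Of the three groups shown at this place, only 3,4-dichlorophenyl comes without a reported number, and the step between compound 2 and compound 3 cannot be read. Nothing measured here bears on the reason for this outcome.

The compounds shown leave open whether an amine or a carboxylic acid in place of these aromatic groups would give a value clearly apart from those of compound 1 and compound 3. Also open, as far as these compounds go, is what a change on the other benzylidene arm would do, since all three compounds carry 2-methoxyphenyl there.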